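From 3-hydroxyphenyl to 4-bromophenyl on a shared core

This account rests on a few compounds, and the source may have more. Where it says the series, first, only, none or still open, it means among the compounds named here.

- Compound 1 `COc1cc(C(=O)/C=C/c2cc(O)ccc2O)cc(OC)c1OC`: > 100000 nM (a limit, not a number)
- Compound 2 `COc1cc(C(=O)/C=C/c2cccc(O)c2)cc(OC)c1OC`: 94000 nM

Among the compounds with values here, in a functional assay on HepG2 cells (Homo sapiens) for inhibition, read by MTT assay, with a stated time of 48 h (a lower number here means a stronger inhibitor, a higher number a weaker inhibitor), compound 2 holds the only actual number, 94000 nM. Compound 3 `COc1cc(C(=O)/C=C/c2ccc(Br)cc2)cc(OC)c1OC` differs from compound 2 at one place: 4-bromophenyl in place of 3-hydroxyphenyl on a double-bonded chain carbon bound to a double-bonded chain carbon. Within the data shown here, the sole measured step, an at least 1.0-fold lower number from compound 1 to compound 2 (0.02 log units; that floor lies within the scatter), is hydrogen in place of hydroxy on an aromatic carbon. Among the measured compounds shown here, it bears only partly on this change, since no measured compound carries bromine. A modest move to a lower number is expected, and the expected step is a 2.4-fold lower number from compound 2 to compound 3 (0.37 log units; beyond the scatter). For compound 3 the estimated value is 40000 nM, with an expected range from 12000 nM to 110000 nM.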

Compound 3, half-maximal inhibitory concentration: 80000 nM
The estimate for compound 3 lay 2.0-fold (0.30 log units) below the measured number, within the range that was stated.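

In this assay the change to 4-bromophenyl gives a 1.2-fold lower number from compound 2 to compound 3 (0.07 log units; within the scatter) and so shows that a group with 0 hydrogen-bond donors and one with 1 read alike at this place on the chain. The step from the 2,5-dihydroxyphenyl group gives an at least 1.2-fold lower number from compound 1 to compound 3 (0.09 log units; that floor lies within the scatter) and adds no clear difference. Compound 1 holds a limit, not a number: the limit of > 100000 nM in this assay, at which 1 of the 3 values shown sits.

Going by these compounds, whether an amine or a carboxylic acid at this place would give a clearly different number stays open. So does whether any group on the shared core brings a much lower number.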